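Adding chloro to the strongest trimethoxy analogue

A few compounds are considered here, and "the series" means these few. Any claim that something is new, unique, unknown or untested is made for them only; others in the source may bear on it.

Compounds measured in a functional assay on UACC-257 cells (Homo sapiens) for inhibition; on this read-out lower numbers stand for stronger inhibition of growth and higher numbers for weaker inhibition of growth:
- compound 1, `COc1cc(/C=C/C(=O)c2cccc(-n3cc(-c4ccc(Cl)cc4)[nH]c3=O)c2)ccc1O`: 8690 nM
- compound 2, `COc1cc(/C=C/C(=O)c2cccc(-n3cc(-c4ccccc4)[nH]c3=O)c2)cc(OC)c1OC`: 1520 nM
- compound 3, `COc1cc(/C=C/C(=O)c2cccc(-n3cc(-c4ccccc4)[nH]c3=O)c2)ccc1O`: 6810 nM

Among these three, compound 2 gives the lowest number, and both compound 3 and compound 1 stand beyond the scatter above it, so compound 2 is the strongest inhibitor of growth measured here.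

The unmeasured compound 4, `COc1cc(/C=C/C(=O)c2cccc(-n3cc(-c4ccc(Cl)cc4)[nH]c3=O)c2)cc(OC)c1OC`, differs from compound 2 in one place: chloro in place of hydrogen on an aromatic carbon.

For the measured compounds named here, only one measured step bears on this change, and it runs the opposite way: a 1.3-fold lower number from compound 1 to compound 3 (0.11 log units; within the scatter). Read in the direction of adding chloro, it suggests that putting chloro in place of hydrogen at this position changes the number little, if at all, on the core that compound 1 and compound 3 share. Compound 4 carries the same change on the core of compound 2, so the expectation is a step of no clear size in this assay, with at most a slight drift toward a higher number.

Compound 4 is therefore expected to give about 1900 nM in this assay, with a range from 900 nM to 4000 nM, which amounts to an expected step of a 1.3-fold higher number from compound 2 to compound 4 (0.10 log units; within the scatter).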

Compound 4, concentration for 50% growth inhibition: 17400 nM
For compound 4 the middle estimate is 9.2-fold (0.96 log units) below the measured one; measured number outside the range, above it.
By their numbers in this assay, from the lowest: compound 2; then compounds 3, 1 and 4 (each within the scatter of the next, the first and the last beyond it).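

In this assay, the change from phenyl to 4-chlorophenyl carries a large cost on the core of compound 2, with an 11-fold higher number from compound 2 to compound 4 (1.06 log units; beyond the scatter). The earlier pair, compound 1 and compound 3, had shown no clear effect of this change, so the effect of chloro at this position depends on the rest of the molecule, and a step read on one core cannot simply be carried over to another: the same change on two cores in this assay, a 1.3-fold lower number (0.11 log units; within the scatter) from compound 1 to compound 3 and an 11-fold lower number (1.06 log units; beyond the scatter) from compound 4 to compound 2, 9.0-fold (0.95 log units) apart, beyond the scatter of two such steps Chloro at this place on the ring therefore makes little clear difference on one core and markedly weakens growth inhibition on the other, although two pairs of compounds are too few to support a general rule.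

With only hydrogen and chloro compared at this position, the compounds shown leave open whether the loss on the core of compound 2 is specific to chloro or would also appear with another group there, such as fluoro, methyl or an amine. The compounds shown do not explain the gap between the two cores. A single read-out of growth inhibition cannot settle that question.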